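Swapping the sulfonyl aryl group: from nitrile to acetamidothiazole

The source may hold more compounds than are shown below. What is called first, only, known or untested is meant among the compounds shown, and "the series" means these compounds.

Of the compounds shown here, two have been measured so far in an ADME assay (liver) for metabolic stability, with Liver microsome (Homo sapiens) as the target, read by LC-MS, using microsomes and NADPH, with a stated time of 5 min, at 37 degrees C; on this read-out higher numbers stand for fast clearance and lower numbers for slow clearance. Compound 1 `CCn1c(C(C)NS(=O)(=O)c2ccc(Cl)cc2)nc2cnccc21` gives 35 mL.min-1.g-1 in this assay. Compound 2 `CCn1c([C@@H](C)NS(=O)(=O)c2ccc(C#N)cc2)nc2ccc(C(F)(F)F)cc21` gives 34 mL.min-1.g-1 in this assay, and these two numbers sit within the usual scatter of one another, so neither compound can be called faster or slower cleared than the other; compound 2 simply holds the lower of the two numbers by a margin too small to mean anything. Among the compounds with values here, no two measured compounds differ in just one place, so no single-point step is available as a guide.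

Compound 3 `CCn1c([C@@H](C)NS(=O)(=O)c2cnc(NC(C)=O)s2)nc2ccc(C(F)(F)F)cc21` has not yet been measured in this assay. It differs from compound 2 in one place: 2-acetamido-1,3-thiazol-5-yl in place of 4-cyanophenyl on a sulfonyl sulfur. Within the data shown here, with no comparable step among the measured compounds, the direction of any change is open, and the expectation rests on compound 2 alone. Compound 3 is therefore expected to give a number close to that of compound 2, with the step of a 1.0-fold higher number from compound 2 to compound 3 (0.01 log units; within the scatter) expected to fall within the scatter. The estimate for compound 3 in this assay is 35 mL.min-1.g-1, within a range from 15 mL.min-1.g-1 to 80 mL.min-1.g-1.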

Compound 3, intrinsic clearance in microsomes: 15 mL.min-1.g-1
For compound 3 the middle estimate is 2.3-fold (0.37 log units) above the measured one; the measured number falls inside the stated range.
By their numbers in this assay, from the lowest: compound 3; then compounds 2 and 1 (each within the scatter of the next).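

The group on the sulfonyl sulfur proves to be a place where the number can move in this assay: 2-acetamido-1,3-thiazol-5-yl in place of 4-cyanophenyl gives a 2.3-fold lower number from compound 2 to compound 3 (0.36 log units; beyond the scatter), a modest change with the rest of the molecule held constant. Within the data shown here, compounds 1 and 2 differ in more than one place, so they could not isolate this position, and this is the first single-place comparison to show a change beyond the scatter. The change swaps a six-membered aromatic ring of carbon only and a triple bond for a five-membered aromatic ring with 2 hetero atoms and an acetamido group, but no available evidence bears on why the number falls.

Going by these compounds, it remains open whether the lower number goes with the thiazole ring, the acetamido group or the two together, and whether the same exchange would have a similar effect on the core of compound 1. A 4-acetamidophenyl group or a 2-amino-1,3-thiazol-5-yl group on the sulfonyl sulfur would help to separate the contributions of the ring and the acetamido group.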